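The compounds below may be only part of what the source reports. "The series", "measured", "known", "first", "only" and "open" are said of these compounds alone.

Measured so far:
- compound 1 `CC(C)S(=O)(=O)N(C)c1ccc(N(C)S(=O)(=O)c2ccc(F)cc2)cc1`: 0.01 mg/kg
- compound 2 `CCC(=O)N[C@H]1CC[C@@H](NC(=O)CC)CC1`: 1 mg/kg
- compound 3 `CC(C)S(=O)(=O)Nc1ccc(NC(=O)c2ccccc2)cc1`: 10 mg/kg

In a functional assay on the whole organism with Mus musculus as the target, with a stated time of 20 min (a lower number here means that less compound is needed, a higher number that more compound is needed for the effect), compound 1 gives 0.01 mg/kg, the lowest of the three numbers; in this assay compound 2 gives 1 mg/kg and compound 3 gives 10 mg/kg, both well beyond the scatter from compound 1. Among the measured compounds shown here, compound 1 thus stands at the favourable end of the set, and the other two differ from it in several places at once, so no single-change step between measured compounds is available.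

Compound 4 `CC(C)S(=O)(=O)Nc1ccc(N(C)S(=O)(=O)c2ccc(F)cc2)cc1` is the next single change from compound 1: hydrogen in place of methyl on a sulfonamide nitrogen. Compound 3, the weakest of the set, also carries a hydrogen on that sulfonamide nitrogen, but it differs from compound 1 elsewhere too, so the value of compound 3, 10 mg/kg, only hints at the direction. A step somewhat beyond the scatter, toward a higher dose, is expected, with the estimate for compound 4 in this assay at 0.03 mg/kg (range 0.005 mg/kg to 0.3 mg/kg), an expected step of a 3.0-fold higher number from compound 1 to compound 4 (0.48 log units; beyond the scatter).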

Compound 4, minimum effective dose: 0.1 mg/kg
For compound 4 the middle estimate is 3.3-fold (0.52 log units) below the measured one; measured number inside the range.
By their numbers in this assay, from the lowest: compound 1; then compound 4; then compound 2; then compound 3.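

Hydrogen in place of methyl on a sulfonamide nitrogen, here with an aromatic carbon and a sulfonyl sulfur as its other neighbours, gives in this assay a 10-fold higher number from compound 1 to compound 4 (1.00 log units; beyond the scatter) and stays beyond the scatter. Among the compounds shown here, this is the only step that isolates one place, so the dose needed can be tied to the methyl on this nitrogen alone, which compound 3 could not show because it differs from compound 1 in other places too. No measurement at hand accounts for the size of this step.

As far as these compounds go, whether the same change on the other sulfonamide nitrogen of compound 1 has a comparable effect remains open. Also open, from the compounds shown here alone, is how an ethyl group, a longer chain or a chain ending in a carboxylic acid would compare with methyl on this nitrogen.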